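A few compounds are considered here, and "the series" means these few. Any claim that something is new, unique, unknown or untested is made for them only; others in the source may bear on it.

Compound 1 `O=C(Nc1cccc(CNc2nccnc2Cl)c1)Nc1cccc2ccccc12`, compound 2 `O=C(Nc1cccc(CNc2nccnc2Cl)c1)Nc1ccc(Cl)cc1Br` and compound 3 `CCc1ccc(NC(=O)Nc2cccc(CNc3nccnc3Cl)c2)c(CC)c1` were tested in a functional assay on HepG2 cells (Homo sapiens) for antiproliferative activity, read by MTT assay, with a stated time of 48 h; on this read-out higher numbers stand for weaker inhibition and lower numbers for stronger inhibition.

Compound 1 gives only a limit in this assay, > 40000 nM, (the limit of > 40000 nM in this assay, at which 1 of the 3 values shown sits). Compound 2 gives 6720 nM. Compound 3 gives 10800 nM, which sits within the usual scatter of compound 2, so no order between the two can be read from them; compound 2 thus stands at one end of the two numbers, with compound 3 beside it.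

Compound 4 `Cc1cccc(NC(=O)Nc2cccc(CNc3nccnc3Cl)c2)c1` differs from compound 2 in one place: 3-methylphenyl in place of 2-bromo-4-chlorophenyl on an amide-type nitrogen. Within the data shown here, no measured pair shows this kind of change, so the expected step of a 1.8-fold higher number from compound 2 to compound 4 (0.25 log units; within the scatter) is taken as small, toward weaker inhibition, and possibly not beyond the scatter. Compound 4 is therefore expected to give about 12000 nM, between 4000 nM and 40000 nM.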

Compound 4, half-maximal inhibitory concentration: 11200 nM
Compound 4: the middle estimate sits 1.1-fold (0.03 log units) above what was measured; low and high end bracket the measured number.
By their numbers in this assay, from the lowest: compounds 2, 3 and 4 (each within the scatter of the next). At a limit, above all of these: compound 1.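

Among these compounds, on the amide-type nitrogen, 3-methylphenyl in place of 2-bromo-4-chlorophenyl gives a 1.7-fold higher number from compound 2 to compound 4 (0.22 log units; within the scatter) in this assay and so provides the first direct reading at this position. The two groups cannot be told apart here, even though the chlorine and the bromine are gone and a single methyl group is present instead. Nothing measured here speaks to the reason for this result.

Because the pair changes several atoms at once, it does not separate the chlorine from the bromine. As far as these compounds go, whether a methoxy group, an amine or a carboxylic acid on this phenyl ring would move the number beyond the scatter remains open.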